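The compounds below may be only part of what the source reports. "The series", "measured", "known", "first", "only" and "open" are said of these compounds alone.

All three measured compounds were read in a functional assay on A2780/DX3 cells (Homo sapiens) for antiproliferative activity, read by MTT assay, with a stated time of 3 days; a lower number here means a stronger inhibitor, a higher number a weaker inhibitor.

Compound 1, `COc1ccc(C2(O)SC=C(C)n3c2noc3=O)cc1`, gives > 100000 nM, which is a limit of the assay and not a number.
Compound 2, `CC1=CSC(O)(c2ccc([N+](=O)[O-])cc2)c2noc(=O)n21`, gives > 100000 nM, likewise a limit.
Compound 3, `CCCCCOC1(c2ccc(Cl)cc2)SC=C(C)n2c1noc2=O`, gives > 100000 nM, again a limit.

Compound 3 therefore stands where every measured compound stands: at the limit of this assay, with no number of its own. The whole set offers a single step, a step that the two limits leave unreadable from compound 1 to compound 2, and its size is not readable; this is the situation described by the limit of > 100000 nM in this assay, at which 3 of the 3 values shown sit. Within the data shown here, nothing among the measured compounds is a step of the same kind as the one now taken, and no gradation of potency exists from which a direction could be drawn.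

Compound 4, `CCCCCCCCCCCCCCCOC1(c2ccc(Cl)cc2)SC=C(C)n2c1noc2=O`, differs from compound 3 in one place: decyl in place of hydrogen on a saturated chain carbon, five bonds along the chain from an oxygen on a saturated carbon. Among the measured compounds shown here, no measured step bears on this change, and the one step that exists is unreadable, so the expectation for compound 4 in this assay rests on nothing more than the position of compound 3, which is the limit. The most likely outcome for compound 4 is estimated to be another limit rather than a number, and the estimate for compound 4 is 100000 nM, ranging from 20000 nM to 300000 nM. For the measured compounds named here, this estimate means the step of a number no higher from compound 3 to compound 4 (the limit leaves the size open), that is, no step expected beyond the scatter.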

Compound 4, half-maximal inhibitory concentration: > 100000 nM
Compound 4 ended at the assay's limit; the forecaster's own chance of this, stated with the estimate: 85%; the middle value lies on the limit itself.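

The step from compound 3 to compound 4 cannot be read, and neither compound has a number of its own in this assay: the limit of > 100000 nM in this assay, at which 4 of the 4 values shown sit.

The compounds shown leave open whether any change on the shared core, including the length of the chain, would bring a readable potency in this assay.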